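Compound 3 to compound 4: a new group on the carbonyl

The source may report more compounds than this note shows. Statements on the series, on what has been measured and on what is new or still open speak of the compounds shown alone.

In a functional assay on SK-OV-3 cells (Homo sapiens) for antiproliferative activity, read by MTT assay (on this read-out higher numbers stand for weaker inhibition and lower numbers for stronger inhibition), compound 1 `O=C1NC(c2ccccc2)CN1S(=O)(=O)c1ccc2c(c1)CCCN2` gives 10400000 nM, and compound 2 `O=C1NC(c2ccccc2)CN1S(=O)(=O)c1ccc2c(c1)CCCN2C(=O)C(F)(F)F` gives 19600 nM. Compound 3 `CC1(c2ccccc2)CN(S(=O)(=O)c2ccc3c(c2)CCCN3C(=O)C(F)(F)F)C(=O)N1` has no number, only a limit of > 20000 nM.

Compound 4 `CSc1ccc(NC(=O)N2CCCc3cc(S(=O)(=O)N4CC(C)(c5ccccc5)NC4=O)ccc32)cc1` keeps the rest of compound 3 and carries (4-(methylsulfanyl)phenyl)amino in place of trifluoromethyl on a carbonyl carbon.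

Within the data shown here, two measured steps bear on this change. The large step of a 530-fold lower number from compound 1 to compound 2 (2.72 log units; beyond the scatter) introduces the carbonyl-bearing group at the same place, so changes there can move this assay strongly. The step of an at least 1.0-fold higher number from compound 2 to compound 3 (0.00 log units; that floor lies within the scatter) has a floor within the scatter and gives little guidance. Among the measured compounds shown here, no measured step replaces trifluoromethyl itself, so the size of this step is poorly bounded.

A moderate step towards stronger inhibition is expected, though a second limit remains possible. The expected change is an at least 5.0-fold lower number from compound 3 to compound 4 (0.69 log units; beyond the scatter). Compound 4 is estimated at 4000 nM. The estimated range for compound 4 runs from 300 nM to 30000 nM.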

Compound 4, half-maximal inhibitory concentration: > 20000 nM
Compound 4: only a limit was reported; the forecaster's own chance of this, stated with the estimate: 25%; middle value at least 5.0-fold (0.69 log units) from the limit.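

In this assay compound 4 gives > 20000 nM, a limit and not a number. No step from compound 3 to compound 4 can be read, as compound 3 also stands only at a limit: the limit of > 20000 nM in this assay, at which 2 of the 4 values shown sit.

Open: whether (4-(methylsulfanyl)phenyl)amino in place of trifluoromethyl shifts inhibition at all.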